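A few compounds are considered here, and "the series" means these few. Any claim that something is new, unique, unknown or untested is made for them only; others in the source may bear on it.

Series notes, cytotoxicity set. Compound 1 `CCc1cccc2c(O)c(-c3occ(C)c3C(=O)O)ccc12` has been measured in a functional assay on ZR-75-1 cells (Homo sapiens) for cytotoxicity, read by MTT assay, with a stated time of 72 h (on this read-out lower numbers stand for an effect already at smaller amounts and higher numbers for an effect only at larger amounts of compound), and gives 0.3 ug/mL. Compound 2 `CCCOC(=O)c1c(C)coc1-c1ccc2c(CC)cccc2c1OC` reports only a limit in this assay, > 10 ug/mL. Compound 3 `CCc1cccc2c(OC(C)=O)c(-c3occ(C)c3COC(C)=O)ccc12` likewise reaches only a limit in this assay, > 10 ug/mL. Within the data shown here, compound 2 therefore stands at the limit of > 10 ug/mL in this assay, at which 2 of the 3 values shown sit, with compound 3 beside it at the same limit, while compound 1 is the only member of the three with a number inside the measured range. Among the measured compounds shown here, no pair of measured compounds differs in a single place, so no measured step is available and the values are read as they stand.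

Compound 4 `CCc1cccc2c(OC)c(-c3occ(C)c3COCC(F)(F)F)ccc12` has not yet been measured in this assay. Going from compound 2 to compound 4 the structure changes as follows: (2,2,2-trifluoroethoxy)methyl in place of propoxycarbonyl on an aromatic carbon. Nothing measured in the series covers this change. The step from compound 2 to compound 4 , a step that the limit leaves unreadable from compound 2 to compound 4, is expected to lie within the scatter and not beyond it, because compound 2 and compound 3 both sit at the limit of > 10 ug/mL in this assay, at which 2 of the 3 values shown sit. Compound 4 is estimated at 15 ug/mL in this assay, with a range from 5 ug/mL to 50 ug/mL, and it is expected that the assay will most likely again report only a limit rather than a number.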

Compound 4, concentration for half-maximal effect: 5.3 ug/mL
The estimate for compound 4 lay 2.8-fold (0.45 log units) above the measured number; the measured number falls inside the stated range.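

Among these compounds, at this position, two ring bonds from the ring oxygen, the earlier compounds offered no readable step, and compound 2 reports only a limit in this assay, > 10 ug/mL. With (2,2,2-trifluoroethoxy)methyl in place of propoxycarbonyl, compound 4 gives a number in this assay, 5.3 ug/mL, so a group without a carbonyl at this position still allows a value inside the measured range, and the change reads as an at least 1.8-fold lower number from compound 2 to compound 4 (0.27 log units; that floor lies within the scatter). That figure is a floor and not the size of the step, and the true size stays unread because compound 2 gives no number: the limit of > 10 ug/mL in this assay, at which 2 of the 4 values shown sit.

On these data alone, the role of the fluorine atoms remains open, since a plain ethoxymethyl group at this position would be needed to separate them from the ether link, and an amide or a primary amine there would show whether other kinds of group are tolerated. Compound 1 differs from compound 4 in more than one place, so the shown compounds do not tell how much of the gap between their values belongs to this position.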